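A few compounds are considered here, and "the series" means these few. Any claim that something is new, unique, unknown or untested is made for them only; others in the source may bear on it.

Of the compounds shown here, two of a shared core have been measured in an assay on isolated protein for inhibition of Amine oxidase [flavin-containing] A (Homo sapiens), read by fluorescence, with a stated time of 30 min; a lower number here means a stronger inhibitor, a higher number a weaker inhibitor. Compound 1 `COc1ccccc1CN(C)CCCCn1sc2cc(OC)c(OC)cc2c1=O` gives 7100 nM. Compound 2 `CCN(CCCCn1sc2cc(OC)c(OC)cc2c1=O)Cc1ccccc1OC` gives 9600 nM. On these two numbers compound 2 stands highest, and its nearest neighbour is compound 1, a 1.4-fold higher number from compound 1 to compound 2 (0.13 log units; within the scatter); the two values are therefore within the scatter of each other, and no order between them can be read.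

The next compound, compound 3 `CCN(CCCCn1sc2cc(OC)c(OC)cc2c1=O)Cc1ccc(N(C)C)cc1`, differs from compound 2 in one place: 4-(dimethylamino)phenyl in place of 2-methoxyphenyl on a saturated chain carbon bound to an amine nitrogen. Among the compounds with values here, no measured step touches this part of the structure. Within the data shown here, the only step that has been measured, a 1.4-fold higher number from compound 1 to compound 2 (0.13 log units; within the scatter), concerns a different site, on the nitrogen side of the chain, and it stayed within the scatter. Among the measured compounds shown here, it thus says nothing about what an exchange of the aromatic ring should do, and there is no second pair from which the effect of the 4-(dimethylamino)phenyl group could be read.

For the measured compounds named here, with no bearing step, the expectation for compound 3 is that it will stay close to compound 2, a step of a 1.1-fold lower number from compound 2 to compound 3 (0.03 log units; within the scatter), and its value in this assay is estimated at 9000 nM, with a range from 2500 nM to 35000 nM that is kept wide because no measured step informs this change.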

Compound 3, half-maximal inhibitory concentration: 15900 nM
The estimate for compound 3 lay 1.8-fold (0.25 log units) below the measured number; the range from low to high includes it.
By their numbers in this assay, from the lowest: compounds 1, 2 and 3 (each within the scatter of the next, the first and the last beyond it).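

Within the data shown here, the exchange of 2-methoxyphenyl for 4-(dimethylamino)phenyl is the first measured change at this place, on a saturated chain carbon bound to an amine nitrogen, and in this assay it gives a step that stays within the scatter (a 1.7-fold higher number from compound 2 to compound 3 (0.22 log units; within the scatter)). Compound 2 and compound 3 therefore cannot be put in order, even though the substituent on the ring differs in kind and the ring carries it under a different name. Among these compounds, at the level of this one pair, then, the 2-methoxybenzyl and 4-(dimethylamino)benzyl groups cannot be told apart in this assay, and nothing measured so far bears on this result or offers an account of it.

On these data alone, what stays open is whether any group at this place would carry the number beyond the scatter, such as a plain phenyl, or a phenyl bearing a nitrile or a carboxylic acid. The compounds shown also leave open whether a propyl group on the amine nitrogen would behave as the methyl and ethyl versions do.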